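A Small Amide Swap on a Shared Core

The source may report more compounds than this note shows. Statements on the series, on what has been measured and on what is new or still open speak of the compounds shown alone.

In an ADME assay on L02 cells (Homo sapiens) for antiproliferative activity, read by MTT assay, with a stated time of 48 h (a lower number here means a stronger inhibitor, a higher number a weaker inhibitor), compound 3 (`CCn1c(C(=O)N(C)CC(=O)O)ccc1C(CC)(CC)c1ccc(OCCC(O)(CC)CC)c(C)c1`) gives 2150 nM and sits level with compound 1 (`CCN(CC)CCNC(=O)c1ccc(C(CC)(CC)c2ccc(OCCC(O)(CC)CC)c(C)c2)n1CC`), which gives 2290 nM as its value. That closeness is the step of a 1.1-fold lower number from compound 1 to compound 3 (0.03 log units; within the scatter) and nothing more can be read from it. Compound 2 (`CCn1c(C(=O)N(CCC#N)CCC#N)ccc1C(CC)(CC)c1ccc(OCCC(O)(CC)CC)c(C)c1`) stands well apart at 37800 nM on the same scale, as the steps of a 17-fold higher number from compound 1 to compound 2 (1.22 log units; beyond the scatter) and an 18-fold lower number from compound 2 to compound 3 (1.25 log units; beyond the scatter) make clear.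

Compound 4 (`CCn1c(C(=O)NC(C)CO)ccc1C(CC)(CC)c1ccc(OCCC(O)(CC)CC)c(C)c1`) keeps the shared core, and the change is (1-(hydroxymethyl)ethyl)amino in place of (carboxymethyl)(methyl)amino on a carbonyl carbon on a carbonyl carbon. Neither group has a ring or a net charge. The nearest guide is the step of a 1.1-fold lower number from compound 1 to compound 3 (0.03 log units; within the scatter). Two different groups at this place gave the same reading there. Compound 2 warns that this place can also shift the number strongly, through an 18-fold lower number from compound 2 to compound 3 (1.25 log units; beyond the scatter) as the case in point. A small move is therefore expected, and the estimated step is a 1.6-fold higher number from compound 3 to compound 4 (0.21 log units; within the scatter) in this assay with a slight lean towards weaker inhibition. The estimated value for compound 4 is 3500 nM (1300 nM to 14000 nM).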

Compound 4, half-maximal inhibitory concentration: 4840 nM
Compound 4: middle estimate off by 1.4-fold (0.14 log units), on the low side; low and high end bracket the measured number.
By their numbers in this assay, from the lowest: compounds 3 and 1 (each within the scatter of the next); then compound 4; then compound 2.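

In this assay, among the compounds shown here, the step of a 2.3-fold higher number from compound 3 to compound 4 (0.35 log units; beyond the scatter) shows a change at this carbonyl carbon that lies beyond the scatter yet is far smaller than the one seen with compound 2. The entering (1-(hydroxymethyl)ethyl)amino group also sets compound 4 apart from compound 1, through a 2.1-fold higher number from compound 1 to compound 4 (0.33 log units; beyond the scatter), so two groups that read level do not mean that every group at this place reads the same. Compound 4 remains on the stronger side of compound 2, as a 7.8-fold lower number from compound 2 to compound 4 (0.89 log units; beyond the scatter) shows, and no measurement here explains any of these shifts.

As far as these compounds go, how much the hydroxyl of the entering group contributes stays open, and isopropylamino, the same chain without that oxygen, would address this. Also open, from the compounds shown here alone, is where a ring amine such as morpholine would fall on the same carbonyl carbon.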